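Swapping a Sulfamoyl for a Boronate Ester on an Aromatic Ring

The source may hold more compounds than are shown below. What is called first, only, known or untested is meant among the compounds shown, and "the series" means these compounds.

Compound 1, with the structure `NS(=O)(=O)c1ccc(COc2ccc(CNC(=O)[C@@H]3CCC(=O)N3Cc3ccc(F)cc3)cc2)cc1`, was tested in an assay on HEK293 cells for inhibition of Ataxin-2 (Mus musculus), read by fluorescence and Amplex Red; on this read-out higher numbers stand for weaker inhibition and lower numbers for stronger inhibition. In this assay compound 1 gives only a limit, > 5000 nM, and not a number. Its close relative compound 2, `NS(=O)(=O)c1ccc(COc2ccc(CNC(=O)[C@@H]3CCC(=O)N3Cc3ccc(C(F)(F)F)cc3)cc2)cc1`, carries a trifluoromethyl in place of fluoro on an aromatic carbon. In this assay compound 2 likewise reaches only a limit, > 5000 nM. The step that the two limits leave unreadable from compound 1 to compound 2 therefore cannot be read in size or direction; the only thing known is the limit of > 5000 nM in this assay, at which 2 of the 2 values shown sit.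

Compound 3, `CC1(C)OB(c2ccc(COc3ccc(CNC(=O)[C@@H]4CCC(=O)N4Cc4ccc(F)cc4)cc3)cc2)OC1(C)C`, has not yet been measured. It differs from compound 1 in one place: a group of 9 heavy atoms (6 carbon, 1 boron, 2 oxygen; one five-membered non-aromatic ring with 3 hetero atoms) in place of a group of 4 heavy atoms (1 nitrogen, 2 oxygen, 1 sulfur; no ring), on an aromatic carbon. No measured step touches this position, so nothing shown tells how the change acts. Within the data shown here, the only anchor is that compound 1 sits at a limit, and the expectation is that compound 3 also sits there, giving a step that the limit leaves unreadable from compound 1 to compound 3 that cannot be called a real change.

On that basis compound 3 is estimated at 9000 nM in this assay, within 2500 nM to 40000 nM.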

Compound 3, half-maximal inhibitory concentration: 120 nM
Compound 3: the middle estimate sits 75-fold (1.88 log units) above what was measured; the whole stated range lies above it.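

Putting the boronate ester in place of the sulfamoyl gives an at least 41-fold lower number from compound 1 to compound 3 (1.61 log units; beyond the scatter) in this assay, which shows that this position, para to a large group, can strongly change the read-out; a lower number here means stronger inhibition. The earlier compounds could not show this, since both carry the sulfamoyl and the step between them cannot be read, and the assay gave no actual number for either: the limit of > 5000 nM in this assay, at which 2 of the 3 values shown sit. The size printed for the new step is only a minimum, and compound 3 is the one compound shown with an actual number, so it is the first firm point for comparing further changes.

The change swaps many features at once, so the compounds shown do not tell whether the gain comes from the boron, from the five-membered ring or from the added carbons, and a free boronic acid, a carboxylic acid or a plain hydrogen at this position would help to separate these. Going by these compounds, it also stays open whether trifluoromethyl in place of fluoro has any readable effect once the boronate ester is present.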